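Chloro to Methoxy on the Anilide Ring of Compound 3

A few compounds are considered here, and "the series" means these few. Any claim that something is new, unique, unknown or untested is made for them only; others in the source may bear on it.

Compound 1 `CCOc1ccc(COc2c(OC)cc(/C=C/C(=O)N3CCN(Cc4ccc(Cl)c(Cl)c4)CC3)cc2OC)cc1`, compound 2 `COc1ccc(/C=C/C(=O)OCC(=O)Nc2ccc(Cl)cc2)cc1OC` and compound 3 `O=C(COC(=O)/C=C/c1ccc(O)c(O)c1)Nc1ccc(Cl)cc1` have been tested in a functional assay on HeLa cells (Homo sapiens) for cytotoxicity, read by MTT assay, with a stated time of 72 h; on this read-out lower numbers stand for stronger inhibition and higher numbers for weaker inhibition. For compound 1 this assay returned only a limit, > 200000 nM. Compound 2 gives 45400 nM. Compound 3 gives 195000 nM, the highest of the two numbers measured, the nearest being compound 2.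

Compound 4 `COc1ccc(NC(=O)COC(=O)/C=C/c2ccc(O)c(O)c2)cc1` has not yet been tested. It differs from compound 3 by methoxy in place of chloro on an aromatic carbon of a six-membered aromatic ring of carbon only. Since compound 3 already sits close to the assay limit, a step from compound 3 to compound 4 of about a 1.1-fold lower number from compound 3 to compound 4 (0.03 log units; within the scatter) is expected, with a fair chance that this assay reports only a limit. Compound 4 is therefore estimated at 180000 nM, within 60000 nM to 400000 nM.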

Compound 4, half-maximal inhibitory concentration: > 200000 nM
Compound 4 was reported as a limit (the forecaster's own chance of this, stated with the estimate: 35%); at least 1.1-fold (0.04 log units) between middle value and limit.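

The change from 4-chlorophenyl to 4-methoxyphenyl gives an at least 1.0-fold higher number from compound 3 to compound 4 (0.01 log units; that floor lies within the scatter) in this assay, so methoxy brings no measurable cytotoxicity at this place. Compound 4 is reported only as a limit, > 200000 nM. The true size of the step cannot be read, because the scale ends there: the limit of > 200000 nM in this assay, at which 2 of the 4 values shown sit.

The compounds shown leave open whether another group at this place, such as an amine or a carboxylic acid, would give a number clear of the limit. They also leave open whether the same change would read differently on the core of compound 2, which gives 45400 nM.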